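A few compounds are considered here, and "the series" means these few. Any claim that something is new, unique, unknown or untested is made for them only; others in the source may bear on it.

Measured so far in an assay on isolated protein for inhibition of aldehyde dehydrogenase 1A1 (Homo sapiens), read by spectrophotometry, tested at 10 uM; a higher number here means more inhibition at the concentration tested (going by the name of the read-out), a lower number less inhibition:
compound 1 `Cc1cccc(Cn2c(CN3CCN(C(=O)c4cccs4)CC3)nc3ccccc32)c1` gives 60.8%;
compound 2 `Cc1cccc(Cn2c(CN3CCN(C(=O)c4ccc(Br)cc4)CC3)nc3ccccc32)c1` gives 25.8%;
compound 3 `Cc1cccc(Cn2c(CN3CCN(C(=O)CC(C)C)CC3)nc3ccccc32)c1` gives 71.4%.

Compound 3 stands highest of the three in this assay: its nearest neighbour is compound 1, and the step of a number 10.6 percentage points higher from compound 1 to compound 3 (beyond the scatter) lies beyond the scatter, while the step of a number 45.6 percentage points higher from compound 2 to compound 3 (beyond the scatter) is large. Compound 4 `Cc1cccc(Cn2c(CN3CCN(C(=O)c4ccco4)CC3)nc3ccccc32)c1` differs from compound 3 by furan-2-yl in place of isobutyl on a carbonyl carbon. The step that bears most on this is a number 10.6 percentage points higher from compound 1 to compound 3 (beyond the scatter), where a five-membered aromatic ring with one hetero atom gave way to isobutyl and the number rose modestly; compound 4 reverses that kind of change, so a modest fall is expected. The large fall a number 35 percentage points lower from compound 1 to compound 2 (beyond the scatter) concerns a six-membered ring and seems less relevant. For compound 4 a step of a number 11.4 percentage points lower from compound 3 to compound 4 (beyond the scatter) is expected, giving an estimated 60%, within 45% to 75%.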

Compound 4, a percentage reported as inhibition, at one concentration (the size of the read-out at that concentration, not a potency): 73.2%
The estimate for compound 4 lay 13.2 percentage points below the measured number; the range from low to high includes it.
By their numbers in this assay, from the lowest: compound 2; then compound 1; then compounds 3 and 4 (each within the scatter of the next).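

In this assay, the change from isobutyl to furan-2-yl on the carbonyl carbon leaves no readable difference, the step being a number 1.8 percentage points higher from compound 3 to compound 4 (within the scatter). An aromatic ring in this place is therefore compatible with the level of the isobutyl compound, yet the ring's identity matters, with a number 12.4 percentage points higher from compound 1 to compound 4 (beyond the scatter) and a number 47.4 percentage points higher from compound 2 to compound 4 (beyond the scatter). Nothing available explains these differences. On these data alone, whether a cyclohexyl group, a longer alkyl chain or a pyridin-3-yl ring on the same carbonyl carbon would read like compound 3 and compound 4 remains open.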